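Shifting a Methyl Group from Compound 3 to Compound 4

This account rests on a few compounds, and the source may have more. Where it says the series, first, only, none or still open, it means among the compounds named here.

The three measured compounds share a core, shown in compound 1 `CC(Oc1ccccc1-c1ccccc1[N+](=O)[O-])C1=NCCN1`, compound 2 `CC(Oc1ccccc1-c1ccc(O)cc1)C1=NCCN1` and compound 3 `Cc1ccccc1-c1ccccc1OC(C)C1=NCCN1`. All three were tested in a functional assay on CHO cells for agonist activity at Alpha-2B adrenergic receptor (Homo sapiens); on this read-out higher numbers stand for larger maximal responses and lower numbers for smaller maximal responses. In this assay compound 1 reaches only a limit, < 0.3. Compound 2 likewise gives only a limit, < 0.3. Compound 3 too stays at a limit, < 0.3, so on the numbers shown it sits no higher than either of its neighbours; all three values rest at the limit of < 0.3 in this assay, at which 3 of the 3 values shown sit. The step that the two limits leave unreadable from compound 1 to compound 3 and the step that the two limits leave unreadable from compound 2 to compound 3 therefore cannot be read in size or direction.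

Compound 4 `Cc1cccc(-c2ccccc2OC(C)C2=NCCN2)c1` has not yet been measured. It differs from compound 3 by 3-methylphenyl in place of 2-methylphenyl on an aromatic carbon. For the measured compounds named here, no measured step resembles this change directly, and the two steps that end at compound 3 are unreadable, so nothing in the data points to a rise beyond the scatter. Since compound 3 gives < 0.3, compound 4 is expected to remain low as well, and the step that the limit leaves unreadable from compound 3 to compound 4 is estimated to stay within the scatter. Compound 4 is thus estimated at 0.2 in this assay, with a range from 0.1 to 0.35, and most likely it will again be reported only as a limit.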

Compound 4, intrinsic activity: the largest response reached, as a fraction of the reference agonist's: < 0.3
Compound 4: a limit, no number; the forecaster's own chance of this, stated with the estimate: 75%; the middle value does not contradict the limit.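

In this assay compound 4 gives < 0.3, which is a limit and not a number. The steps to compound 4 from compound 2 and from compound 3 therefore cannot be read in size or direction: the limit of < 0.3 in this assay, at which 4 of the 4 values shown sit. The compounds shown leave open whether 3-methylphenyl and 2-methylphenyl differ at all in this assay, and how far any of the four compounds lies under the limit.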